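A few compounds are considered here, and "the series" means these few. Any claim that something is new, unique, unknown or untested is made for them only; others in the source may bear on it.

In an ADME assay on Vero cells (Chlorocebus sabaeus) for inhibition (a lower number here means that less compound is tolerated, a higher number that more compound is tolerated), compound 1 (`COc1cccc(/C=C2\CCC/C(=C\c3ccc(Br)cc3)C2=O)c1OC`) gives 31500 nM. Compound 2 (`COc1cccc(/C=C2\CCC/C(=C\c3ccc(F)cc3)C2=O)c1OC`) gives 33200 nM, with fluoro for bromo making a 1.1-fold higher number from compound 1 to compound 2 (0.02 log units; within the scatter). Compound 3 (`COc1cccc(/C=C2\CCC/C(=C\c3ccc([N+](=O)[O-])cc3)C2=O)c1OC`) gives only a limit, < 10000 nM. Nitro for bromo gives an at least 3.1-fold lower number from compound 1 to compound 3 (0.49 log units; beyond the scatter), and nitro for fluoro gives an at least 3.3-fold lower number from compound 2 to compound 3 (0.52 log units; beyond the scatter).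

Compound 4 (`COc1cccc(/C=C2\CCC/C(=C\c3c(Cl)cccc3Cl)C2=O)c1OC`) has 2,6-dichlorophenyl in place of 4-nitrophenyl on a double-bonded chain carbon bound to a double-bonded ring carbon. Within the data shown here, no measured compound carries 2,6-dichlorophenyl, so the nitro steps serve only as a guide, read in reverse. Compound 4 also lacks the nitro group, as does compound 1 at 31500 nM, so a return towards that level is expected. The expected change is an at least 2.5-fold higher number from compound 3 to compound 4 (0.39 log units; beyond the scatter), beyond the scatter. For compound 4 the estimated value is 25000 nM, with an expected range of 10000 nM to 50000 nM.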

Compound 4, half-maximal cytotoxic concentration: 160000 nM
For compound 4 the middle estimate is 6.4-fold (0.81 log units) below the measured one; the whole stated range lies below it.
By their numbers in this assay, from the lowest: compounds 1 and 2 (each within the scatter of the next); then compound 4. At a limit, below all of these: compound 3.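

In this assay, 2,6-dichlorophenyl moves the number clear of both 4-halophenyl compounds, with a 5.1-fold higher number from compound 1 to compound 4 (0.71 log units; beyond the scatter) and a 4.8-fold higher number from compound 2 to compound 4 (0.68 log units; beyond the scatter), so this place on a double-bonded chain carbon bound to a double-bonded ring carbon can shift the read-out upward, whereas fluoro for bromo stayed within the scatter. Against 4-nitrophenyl the change reads an at least 16-fold higher number from compound 3 to compound 4 (1.20 log units; beyond the scatter), which is only a bound: the limit of < 10000 nM in this assay, at which 1 of the 4 values shown sits.

On these data alone, whether the higher number needs both chlorines stays open. So does the reading for an amine or a carboxylic acid on this ring.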